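The source may hold more compounds than are shown below. What is called first, only, known or untested is meant among the compounds shown, and "the series" means these compounds.

Working notes on the series. Compound 1 `OC[C@H]1O[C@@H](Cc2ccccc2)[C@H](O)[C@@H](OCc2ccccc2)[C@@H]1O` and compound 2 `CCCC[C@@H]1O[C@H](COCc2ccccc2)[C@@H](OCc2ccccc2)[C@H](OCc2ccccc2)[C@H]1O` each give no single number in a functional assay on HL-60 cells (Homo sapiens) for antiproliferative activity, read by MTT assay; a lower number here means a stronger inhibitor, a higher number a weaker inhibitor: compound 1 is recorded as "not active" (no number reported), and compound 2 as "not active" (no number reported). Compound 3 `O[C@@H]1[C@@H](OCc2ccccc2)[C@H](OCc2ccccc2)[C@@H](COCc2ccccc2)O[C@H]1CC1CCCCC1` is the one entry with a figure, giving 4100 nM in this assay, so on the numbers shown it stands alone, with no measured neighbour to rank it against. Compound 4 `O[C@H]1CO[C@H](COCc2ccccc2)[C@@H](OCc2ccccc2)[C@@H]1OCc1ccccc1` has not yet been measured. It differs from compound 3 in one place: hydrogen in place of cyclohexylmethyl on a saturated ring carbon. Among the compounds with values here, no step between two measured compounds is available, so the size of this change cannot be read from any tested pair. Since the cyclohexylmethyl group leaves and compound 3 already sits at a weak 4100 nM, the expectation is a shift toward weaker inhibition in this assay, beyond the usual scatter, with a real chance that no number at all comes back. Compound 4 is expected to give about 20000 nM in this assay, within 6000 nM to 80000 nM, meaning an estimated step of a 4.9-fold higher number from compound 3 to compound 4 (0.69 log units; beyond the scatter).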

Compound 4, half-maximal inhibitory concentration: "not active" (no number reported)
Compound 4 has no reported number here; the estimate stays without a comparison.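

In this assay, within the data shown here, compound 4 returns no number, so no step from compound 3 to compound 4 can be read. No evidence bears on this result. The compounds shown leave open how far activity depends on the cyclohexylmethyl group of compound 3.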